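Chloro in Place of Fluoro: What to Expect for Compound 4

The source may hold more compounds than are shown below. What is called first, only, known or untested is meant among the compounds shown, and "the series" means these compounds.

Compound 1 `C=C1C[C@]23C[C@@]1(O)CC[C@H]2c1ccc(O)c(C)c1[C@@H]3Cn1cc(-c2ccccn2)nn1` — > 20000 nM
Compound 2 `Cc1c(O)ccc2c1[C@H](Cn1cc(-c3ccccc3)nn1)[C@@]13CC(=O)[C@@](C)(CC[C@@H]21)C3` — > 20000 nM
Compound 3 `Cc1c(O)ccc2c1[C@H](Cn1cc(-c3ccc(F)cc3)nn1)[C@@]13CC(=O)[C@@](C)(CC[C@@H]21)C3` — > 20000 nM

In a functional assay on SW480 cells (Homo sapiens) for cytotoxicity, read by MTT assay, with a stated time of 4 days (on this read-out lower numbers stand for stronger inhibition and higher numbers for weaker inhibition), compound 1 gives > 20000 nM, which is a limit of the assay. In this assay compound 2 gives > 20000 nM, likewise a limit. In this assay compound 3 gives > 20000 nM, again a limit. Compound 3 therefore stands at the same limit as the other two values shown, and the step that the two limits leave unreadable from compound 2 to compound 3 cannot be read in size or direction. Among the compounds with values here, the evidence is the limit of > 20000 nM in this assay, at which 3 of the 3 values shown sit, so no measured step has a readable magnitude.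

Compound 4 `Cc1c(O)ccc2c1[C@H](Cn1cc(-c3ccc(Cl)cc3)nn1)[C@@]13CC(=O)[C@@](C)(CC[C@@H]21)C3` differs from compound 3 as follows: chloro in place of fluoro on an aromatic carbon. Within the data shown here, the only measured step that bears on this change is the one from compound 2 to compound 3, and its size is unreadable. With no readable step in this assay, no change beyond the scatter is expected, and compound 4 is expected to remain at the limit. Compound 4 is estimated at 30000 nM, with a range of 10000 nM to 100000 nM. The expected step is a step that the limit leaves unreadable from compound 3 to compound 4.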

Compound 4, half-maximal inhibitory concentration: > 20000 nM
Compound 4 gave a limit, no number (the forecaster's own chance of this, stated with the estimate: 85%); the middle value does not contradict the limit.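

In this assay compound 4 gives > 20000 nM, a limit, so the steps to it from compound 2 and compound 3 cannot be read: the limit of > 20000 nM in this assay, at which 4 of the 4 values shown sit. The compounds shown leave open whether hydrogen, fluoro and chloro at this place differ in cytotoxicity at all.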